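The compounds below may be only part of what the source reports. "The series", "measured", "known", "first", "only" and "open" are said of these compounds alone.

Measured in a functional assay on B16-F10 cells (Mus musculus) for antiproliferative activity, read by MTT assay, with a stated time of 48 h; a lower number here means a stronger inhibitor, a higher number a weaker inhibitor:
- compound 1 `Cc1ccc(-c2cc(NC(=O)/C=C/c3ccc(Cl)cc3)n[nH]2)cc1` gives 1520 nM
- compound 2 `O=C(/C=C/c1ccc(Cl)cc1)Nc1cc(-c2ccccc2)[nH]n1` gives 1270 nM
- compound 3 `O=C(/C=C/c1ccc(Cl)cc1)Nc1cc(-c2ccc(Br)cc2)[nH]n1` gives 1080 nM

Compound 1 stands level with compound 2 and compound 3, and no order can be read among the three (a 1.2-fold lower number from compound 1 to compound 2 (0.08 log units; within the scatter); a 1.4-fold lower number from compound 1 to compound 3 (0.15 log units; within the scatter)). The remaining step is just as small (a 1.2-fold lower number from compound 2 to compound 3 (0.07 log units; within the scatter)).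

Compound 4 `COc1ccc(/C=C/C(=O)Nc2cc(-c3ccc(C)cc3)[nH]n2)cc1` differs from compound 1 by one change, 4-chlorophenyl to 4-methoxyphenyl (methoxy in place of chloro on an aromatic carbon). All three measured steps concern the aromatic ring that carries the methyl of compound 1. For the measured compounds named here, none touches the 4-chlorophenyl, so the data hold no direct precedent for this swap. They show only that the series has not moved beyond the scatter so far, and the range is kept wide for that reason.

In this assay no step beyond the scatter is expected, and the estimate amounts to a small one (a 1.1-fold higher number from compound 1 to compound 4 (0.05 log units; within the scatter)). The expected value for compound 4 is 1700 nM (estimated range 700 nM to 4500 nM).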

Compound 4, half-maximal inhibitory concentration: 1370 nM
Estimate against measurement, compound 4: 1.2-fold (0.09 log units) above, within the range that was stated.
By their numbers in this assay, from the lowest: compounds 3, 2, 4 and 1 (each within the scatter of the next).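

In this assay, for the compounds shown here, the earlier steps all concerned the ring carrying the methyl of compound 1, whereas this step reaches the 4-chlorophenyl and stays within the scatter (a 1.1-fold lower number from compound 1 to compound 4 (0.05 log units; within the scatter)). On the aromatic carbon para to a large group, methoxy in place of chloro therefore gives no readable shift, even though the incoming group adds a heavy atom and a hydrogen-bond acceptor. No measured property is available to account for this result.

This single step leaves open whether an amine, a carboxylic acid or a longer alkoxy chain at the same place would also stay within the scatter. It also leaves open whether the same swap would read alike with hydrogen or bromo in place of the methyl on the other ring.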